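Thiophene thiosemicarbazones: methoxy for ethyl on the aryl ring

This account rests on a few compounds, and the source may have more. Where it says the series, first, only, none or still open, it means among the compounds named here.

compound 1 `S=C(N/N=C/c1cccs1)Nc1cccc2ccccc12`: 82400 nM
compound 2 `CCc1ccc(NC(=S)N/N=C/c2cccs2)cc1`: 17600 nM
compound 3 `C=CCNC(=S)N/N=C/c1cccs1`: > 100000 nM

In an ADME assay on HaCaT cells (Homo sapiens) for inhibition, read by sulforhodamine B assay, with a stated time of 48 h (on this read-out lower numbers stand for stronger inhibition of growth and higher numbers for weaker inhibition of growth), compound 2 gives 17600 nM, the lowest of the two numbers obtained; compound 1 gives 82400 nM, a higher number beyond the scatter. Compound 3 gives only a limit of the assay and not a number, sitting at the limit of > 100000 nM in this assay, at which 1 of the 3 values shown sits.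

Compound 4 `COc1ccc(NC(=S)N/N=C/c2cccs2)cc1` differs from compound 2 by methoxy in place of ethyl on an aromatic carbon. Going by the values given here, no measured pair isolates this change, so in this assay the step is expected to be small, most likely within the scatter, with at most a mild shift toward a higher number. Compound 4 is therefore expected at 25000 nM, in the range 8000 nM to 80000 nM. This estimate implies a step of a 1.4-fold higher number from compound 2 to compound 4 (0.15 log units; within the scatter).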

Compound 4, concentration for 50% growth inhibition: > 100000 nM
Compound 4 was reported as a limit; the forecaster's own chance of this, stated with the estimate: 10%; middle value at least 4.0-fold (0.60 log units) away from the limit.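

In this assay, methoxy in place of ethyl on an aromatic carbon, para to a large group, gives an at least 5.6-fold higher number from compound 2 to compound 4 (0.75 log units; beyond the scatter). Going by these compounds alone, no earlier pair differed in one place, so this is the first direct reading at this position, and it shows that growth inhibition here depends on the group even with the same count of heavy atoms. Compound 4 is a limit and not a number: the limit of > 100000 nM in this assay, at which 2 of the 4 values shown sit.

On these data alone, whether a longer chain such as propyl, or an amine, at this position would keep the level of compound 2 remains open. So does whether the step carries over to other substituents on the shared core.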